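A few compounds are considered here, and "the series" means these few. Any claim that something is new, unique, unknown or untested is made for them only; others in the source may bear on it.

Of the compounds shown here, two have been measured in a functional assay on ileum for inhibition of histamine H1 receptor (Cavia porcellus); a higher number here means a weaker inhibitor, a lower number a stronger inhibitor. Compound 1 `CN1CCN(c2nc3ccccc3n2CCOc2ccccc2)CC1` gives 6.9 nM and has the lowest number of the two. Compound 2 `CCOCCn1c(N2CCNCC2)nc2ccccc21` gives 11 nM in this assay; it differs from compound 1 in more than one place, and its number sits within the scatter of that of compound 1, so the two cannot be told apart on these data.

Compound 3 `CCCC(C)Cn1c(N2CCN(C)CC2)nc2ccccc21` has not yet been measured. Relative to compound 1 it carries 1-methylbutyl in place of phenoxymethyl on a saturated chain carbon bound to an aromatic nitrogen. Among the measured compounds shown here, no measured pair isolates this change, so no computed step is available for it; the difference removes a group with one six-membered aromatic ring and one hydrogen-bond acceptor in favour of a group with no ring and no acceptor, on the saturated chain carbon bound to the aromatic nitrogen.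

The expectation for compound 3 in this assay is a modest weakening, a step of a 2.3-fold higher number from compound 1 to compound 3 (0.37 log units; beyond the scatter), just beyond the scatter. Compound 3 is thus estimated at 16 nM, with a range from 5 nM to 50 nM.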

Compound 3, half-maximal inhibitory concentration: 500 nM
Beside the measured number, compound 3's estimate is 31-fold (1.49 log units) below it; measured number above the stated range.
By their numbers in this assay, from the lowest: compounds 1 and 2 (each within the scatter of the next); then compound 3.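

In this assay, among the compounds shown here, this position proves far from indifferent to what it carries: 1-methylbutyl in place of phenoxymethyl on a saturated chain carbon bound to an aromatic nitrogen gives a 72-fold higher number from compound 1 to compound 3 (1.86 log units; beyond the scatter) and is the first step that isolates a single place. The change removes the six-membered aromatic ring of carbon only and the hydrogen-bond acceptor together, and it also takes the group from 8 heavy atoms to 5, so this one large step cannot assign the loss to any one of these differences. No measurement here bears on the reason for the step.

Still open, going by these compounds, is whether the ring, the oxygen or the size of the group accounts for the step, and a single compound with 2-phenylethyl would keep the ring without the oxygen, while one with cyclohexyloxymethyl would keep the oxygen on a saturated ring. Also open, on these data alone, is whether branching within the 1-methylbutyl group plays any part, a question that a straight pentyl chain at the same place could address.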